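The compounds below may be only part of what the source reports. "The series", "measured", "known", "first", "only" and "open" are said of these compounds alone.

Measured compounds in a functional assay on MOLT-4 cells (Homo sapiens) for cytotoxicity, read by sulforhodamine B assay, with a stated time of 48 h, tested at 100 uM; a higher number here means a weaker effect of the compound at the concentration tested, a lower number a stronger effect:
compound 1 `COc1cc(-c2cc(/C=C/C(=O)c3ccc(N)cc3)[nH]n2)cc(OC)c1OC`: -20%
compound 2 `COc1ccc(C(=O)/C=C/c2cc(-c3cc(OC)c(OC)c(OC)c3)n[nH]2)cc1`: -4%

Within the data shown here, compound 2 stands at the higher of the two numbers; the only measured step, a number 16 percentage points higher from compound 1 to compound 2 (beyond the scatter), separates it from compound 1. Compound 3 `COc1cc(-c2cc(/C=C/C(=O)c3ccc(F)c(F)c3)[nH]n2)cc(OC)c1OC` differs from compound 2 by 3,4-difluorophenyl in place of 4-methoxyphenyl on a carbonyl carbon. Among the measured compounds shown here, no measured step concerns this place or this change, so nothing bears on it directly. With compound 2 at -4%, compound 3 is expected to show no step beyond the scatter, a number 1 percentage points lower from compound 2 to compound 3 (within the scatter). Compound 3 is therefore estimated at -5%, within -25% to 15%.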

Compound 3, a percentage reported as activity, at one concentration (the size of the read-out at that concentration, not a potency): -14%
Beside the measured number, compound 3's estimate is 9 percentage points above it, within the range that was stated.
By their numbers in this assay, from the lowest: compounds 1, 3 and 2 (each within the scatter of the next, the first and the last beyond it).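

In this assay the change to 3,4-difluorophenyl on a carbonyl carbon gives a number 10 percentage points lower from compound 2 to compound 3 (within the scatter) and also a number 6 percentage points higher from compound 1 to compound 3 (within the scatter) and so separates compound 3 from neither compound 1 nor compound 2, although those two stand apart beyond the scatter. A ring with no hydrogen-bond donor or acceptor thus reads within the scatter of both 4-aminophenyl and 4-methoxyphenyl at this place. No evidence at hand accounts for these steps. On these data alone, what stays open is how an unsubstituted phenyl or a 4-hydroxyphenyl would read here, and whether a single fluorine would match the pair.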